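Swapping Fluoro for Chloro on the Shared Core

The source may hold more compounds than are shown below. What is called first, only, known or untested is meant among the compounds shown, and "the series" means these compounds.

Compound 1 `O=C(Cc1cccnc1)c1cc2ccccc2[nH]1`: 65000 nM
Compound 2 `COc1ccc2[nH]c(C(=O)Cc3cccnc3)cc2c1`: 49000 nM
Compound 3 `O=C(Cc1cccnc1)c1cc2cc(F)ccc2[nH]1`: 36000 nM

These three compounds were tested in an assay on isolated protein for inhibition of Indoleamine 2,3-dioxygenase 1 (Homo sapiens), read by spectrophotometry; a lower number here means a stronger inhibitor, a higher number a weaker inhibitor. Compound 3 has the lowest of the three numbers, yet a 1.8-fold lower number from compound 1 to compound 3 (0.26 log units; within the scatter) and a 1.4-fold lower number from compound 2 to compound 3 (0.13 log units; within the scatter) both fall within the usual scatter, so the three cannot be told apart with confidence. Compound 4 `O=C(Cc1cccnc1)c1cc2cc(Cl)ccc2[nH]1` has not been measured; it differs from compound 3 by chloro in place of fluoro on an aromatic carbon. The two steps just named are the ones that bear on this position, and hydrogen, methoxy and fluoro there all gave numbers within the scatter of one another. On that basis compound 4 is expected to land near compound 3, with a 1.2-fold lower number from compound 3 to compound 4 (0.08 log units; within the scatter) estimated as no step beyond the scatter. The estimate for compound 4 is 30000 nM, ranging from 12000 nM to 80000 nM.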

Compound 4, half-maximal inhibitory concentration: 24600 nM
For compound 4 the middle estimate is 1.2-fold (0.09 log units) above the measured one, within the range that was stated.
By their numbers in this assay, from the lowest: compounds 4, 3, 2 and 1 (each within the scatter of the next, the first and the last beyond it).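

Going by these compounds alone, at this position on the shared core, chloro is the first group to give a step from hydrogen that lies beyond the scatter in this assay, though a modest one (a 2.6-fold lower number from compound 1 to compound 4 (0.42 log units; beyond the scatter)). Chloro cannot be separated from the other two groups, as both steps stay within the scatter (a 1.5-fold lower number from compound 3 to compound 4 (0.17 log units; within the scatter); a 2.0-fold lower number from compound 2 to compound 4 (0.30 log units; within the scatter)). Nothing on hand explains this result.

Going by these compounds, whether bromo, an amine or a carboxylic acid at this place would give a larger step remains open. So does whether the chloro step would hold with a different group in place of the carbonyl.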